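This account rests on a few compounds, and the source may have more. Where it says the series, first, only, none or still open, it means among the compounds named here.

Measured in an assay on CHO-K1 cells for displacement of a labelled ligand from melanin-concentrating hormone receptor 1 (Homo sapiens), read by scintillation proximity assay, with a stated time of 2 h; a lower number here means a stronger inhibitor, a higher number a weaker inhibitor:
Compound 1 `Cc1nc(N2CCC(N3C(=O)CCC3=O)CC2)nc2ccc(NC(=O)/C=C/c3ccc(OC(F)(F)F)cc3)cc12` gives 94 nM.
Compound 2 `COCCC1(O)CCN(c2nc(C)c3cc(NC(=O)/C=C/c4ccc(Cl)cc4)ccc3n2)CC1` gives 245 nM.
Compound 3 `Cc1nc(NCCNC(=O)C2CC2)nc2ccc(NC(=O)/C=C/c3ccc(OC(F)(F)F)cc3)cc12` gives 61 nM.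

Among these three numbers compound 1 holds the second highest. Its value and that of compound 3 lie within the usual scatter of this assay, so no order between the two can be read from them; compound 2 sits beyond the scatter on the higher, weaker side. Compound 4 `Cc1nc(N2CCC(N3CCNC3=O)CC2)nc2ccc(NC(=O)/C=C/c3ccc(OC(F)(F)F)cc3)cc12` has not yet been measured in this assay. It differs from compound 1 in one place: 2-oxoimidazolidin-1-yl in place of 2,5-dioxopyrrolidin-1-yl on a saturated ring carbon. Going by the values given here, no measured pair shows this same change, so its effect is unknown here. The expected step, a 1.0-fold lower number from compound 1 to compound 4 (0.02 log units; within the scatter), is none beyond the scatter. Compound 4 is therefore estimated at 90 nM, with a range from 35 nM to 230 nM.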

Compound 4, half-maximal inhibitory concentration: 66 nM
Compound 4: the middle estimate sits 1.4-fold (0.13 log units) above what was measured, within the range that was stated.
By their numbers in this assay, from the lowest: compounds 3, 4 and 1 (each within the scatter of the next); then compound 2.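

In this assay, 2-oxoimidazolidin-1-yl in place of 2,5-dioxopyrrolidin-1-yl gives a 1.4-fold lower number from compound 1 to compound 4 (0.15 log units; within the scatter), so on this saturated ring carbon the exchange, which brings in a hydrogen-bond donor, produces no readable change. The step in which 4-(2-oxoimidazolidin-1-yl)piperidin-1-yl replaces (2-((cyclopropylcarbonyl)amino)ethyl)amino on an aromatic carbon is a 1.1-fold higher number from compound 3 to compound 4 (0.03 log units; within the scatter) and also lies within the scatter. Nothing shown here gives a reason for either result.

The compounds shown leave open whether a free amine or a carboxylic acid on that saturated ring carbon would shift the number beyond the scatter.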